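Compound 4: a small ring for an aromatic one

The source may report more compounds than this note shows. Statements on the series, on what has been measured and on what is new or still open speak of the compounds shown alone.

Measured in a functional assay on A549 cells (Homo sapiens) for antiproliferative activity, read by MTT assay, with a stated time of 72 h; a lower number here means a stronger inhibitor, a higher number a weaker inhibitor:
Compound 1 `O=C1COc2ccc(-c3cnc(Cl)c(NS(=O)(=O)c4ccc(F)cc4)c3)cc2N1C1CCCCC1`: 37900 nM
Compound 2 `COc1cccc(N2C(=O)COc3ccc(-c4cccc(NS(=O)(=O)c5ccc(F)cc5)c4)cc32)c1`: > 40000 nM
Compound 3 `COc1ccc(N2C(=O)COc3ccc(-c4cnc5ccccc5c4)cc32)cc1`: > 40000 nM

Compound 2 gives no true number in this assay: its > 40000 nM is a limit. Compound 3 also reports only a limit, > 40000 nM. Together, these two compounds sit at the limit of > 40000 nM in this assay, at which 2 of the 3 values shown sit.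

Compound 4 `O=C1COc2ccc(-c3cccc(NS(=O)(=O)c4ccc(F)cc4)c3)cc2N1C1CC1` keeps the rest of compound 2 and differs in one place: it has cyclopropyl in place of 3-methoxyphenyl on an amide-type nitrogen in a ring. Going by the values given here, no measured pair shows this change on its own, so the data offer no direct guide to its effect. Among the compounds with values here, no step beyond the usual scatter is expected in this assay, in either direction, because compound 1 reads 37900 nM and no compound here shows strong activity. The estimated change is an at least 1.1-fold lower number from compound 2 to compound 4 (0.05 log units; that floor lies within the scatter). For compound 4 the expected value is 35000 nM, with an estimated range from 12000 nM to 60000 nM.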

Compound 4, half-maximal inhibitory concentration: > 40000 nM
Compound 4 ended at the assay's limit (the forecaster's own chance of this, stated with the estimate: 50%); at least 1.1-fold (0.05 log units) between middle value and limit.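

Compound 2 and compound 4 both end at a limit in this assay, so no step can be read between them. The compounds shown leave open what cyclopropyl in place of 3-methoxyphenyl on the amide-type nitrogen in a ring does to the activity, in either direction.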